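Compound 3 to compound 4: an ester in the side chain

A few compounds are considered here, and "the series" means these few. Any claim that something is new, unique, unknown or untested is made for them only; others in the source may bear on it.

compound 1 `COc1ccccc1OCC1SCCN1C(=O)CNC(C)=O`: 40 mg/kg
compound 2 `C=CC(=O)N1CCSC1COc1ccccc1OC`: 74 mg/kg
compound 3 `CCCC(=O)CC(=O)N1CCSC1COc1ccccc1OC`: 42 mg/kg

In a functional assay on the whole organism for inhibition, with Cavia porcellus as the target (a higher number here means that more compound is needed for the effect, a lower number that less compound is needed), compound 3 gives 42 mg/kg, which lies within the scatter of both other compounds. The measured gaps to it are a 1.1-fold higher number from compound 1 to compound 3 (0.02 log units; within the scatter) and a 1.8-fold lower number from compound 2 to compound 3 (0.25 log units; within the scatter).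

Next is compound 4 `CCOC(=O)CCC(=O)N1CCSC1COc1ccccc1OC`, not yet measured. The structural change is (ethoxycarbonyl)methyl in place of propylcarbonyl on a saturated chain carbon bound to a carbonyl carbon.

Going by the values given here, the closest precedent is the exchange at this same place, a 1.1-fold higher number from compound 1 to compound 3 (0.02 log units; within the scatter), where propylcarbonyl replaces acetamido. The two steps on the carbonyl carbon, a 1.9-fold higher number from compound 1 to compound 2 (0.27 log units; within the scatter) and a 1.8-fold lower number from compound 2 to compound 3 (0.25 log units; within the scatter), are larger but also stay inside the scatter. So far, then, the side chain has been varied without a step beyond the scatter in this assay. That rests on three compounds only, and none of them carries the ethoxycarbonyl group, so the precedent is indirect.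

No step beyond the scatter is therefore expected, and no direction can be assigned with confidence. The expected step is a 1.1-fold higher number from compound 3 to compound 4 (0.03 log units; within the scatter). For compound 4 the estimate is 45 mg/kg, with an expected range from 25 mg/kg to 80 mg/kg.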

Compound 4, dose for half-maximal effect: 24 mg/kg
Compound 4: the middle estimate sits 1.9-fold (0.27 log units) above what was measured, outside the stated range (below it).
By their numbers in this assay, from the lowest: compounds 4, 1, 3 and 2 (each within the scatter of the next, the first and the last beyond it).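

In this assay, going by these compounds alone, the ester side chain gives the first step beyond the scatter, though a modest one: 2-(ethoxycarbonyl)ethyl in place of vinyl on a carbonyl carbon (a 3.1-fold lower number from compound 2 to compound 4 (0.49 log units; beyond the scatter)). The other two steps stay within the scatter (a 1.8-fold lower number from compound 3 to compound 4 (0.24 log units; within the scatter); a 1.7-fold lower number from compound 1 to compound 4 (0.22 log units; within the scatter)), so on a saturated chain carbon bound to a carbonyl carbon, (ethoxycarbonyl)methyl cannot be told apart from propylcarbonyl or acetamido. Vinyl on the carbonyl carbon thus stands apart from compound 4 alone and remains within the scatter of compound 1 and compound 3, and the data on hand give no explanation for this gap.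

The compounds shown leave open whether the separation from vinyl belongs to the ester group or to the saturated chain alone, which a plain butyl chain on the carbonyl carbon would help to settle. They also leave open how a carboxylic acid or a primary amine at the end of this chain would read, and whether a longer chain carrying the ester would stay within the scatter of compound 4 (24 mg/kg).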